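The source may report more compounds than this note shows. Statements on the series, on what has been measured and on what is new or still open speak of the compounds shown alone.

Measured in a functional assay on HeLa cells (Homo sapiens) for antiproliferative activity, read by cell counting, with a stated time of 2 days; on this read-out higher numbers stand for weaker inhibition and lower numbers for stronger inhibition:
- compound 1 `CCN(CC)c1nc(N)c(C(=O)c2cc(OC)c(OC)c(OC)c2)s1`: 38000 nM
- compound 2 `COc1cc(C(=O)c2sc(N(C)Cc3ccccc3)nc2N)cc(OC)c1OC`: > 200000 nM

Compound 2 gives only a limit and not a number: it stands at the limit of > 200000 nM in this assay, at which 1 of the 2 values shown sits. Compound 3 `COc1cc(C(=O)c2sc(N3CCCC3)nc2N)cc(OC)c1OC` has pyrrolidin-1-yl in place of benzyl(methyl)amino on an aromatic carbon. Among the compounds with values here, one measured step bears on this change. It is an at least 5.2-fold higher number from compound 1 to compound 2 (0.72 log units; beyond the scatter), which goes with weaker inhibition, beyond the scatter, when benzyl(methyl)amino replaces diethylamino on an aromatic carbon. Pyrrolidin-1-yl is not diethylamino, so that step can only serve as a guide. Even so, a step of at least similar size toward stronger inhibition is expected in this assay, with compound 1 at 38000 nM as the nearest measured value. The expected change is an at least 8.0-fold lower number from compound 2 to compound 3 (0.90 log units; beyond the scatter). The estimate for compound 3 is 25000 nM, with an expected range of 5000 nM to 120000 nM.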

Compound 3, half-maximal inhibitory concentration: 340 nM
Estimate against measurement, compound 3: 74-fold (1.87 log units) above; the measured number lies below the stated range.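

In this assay, the aromatic carbon next to the ring nitrogen and next to the ring sulfur proves able to carry much stronger inhibition than the earlier values suggested: pyrrolidin-1-yl brings an at least 580-fold lower number from compound 2 to compound 3 (2.76 log units; beyond the scatter), and set against diethylamino it brings a 110-fold lower number from compound 1 to compound 3 (2.05 log units; beyond the scatter). The second of these steps joins two measured numbers and so gives the clearest size for the change, since compound 2 has a limit and not a number: the limit of > 200000 nM in this assay, at which 1 of the 3 values shown sits. Of the three compounds, only compound 3 carries a non-aromatic ring at this place, and it gives the strongest inhibition of the three.

Going by these compounds, whether other ring amines, such as piperidin-1-yl or morpholin-4-yl, behave like pyrrolidin-1-yl remains open. So does the effect of a shorter open-chain amine such as dimethylamino, and the three compounds do not show what in pyrrolidin-1-yl accounts for the gain.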